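Chloro Replaced by a Pentyloxy Chain: Expected Dose

The compounds below may be only part of what the source reports. "The series", "measured", "known", "first", "only" and "open" are said of these compounds alone.

Compound 2 `O=C(O)c1cnc(-c2ccccc2Cl)[nH]c1=O` is measured in a functional assay on the whole organism (strain Sprague-Dawley) for inhibition, with Rattus norvegicus as the target, with a stated time of 10 min (a higher number here means that more compound is needed for the effect, a lower number that less compound is needed), where compound 2 needs 5 mg/kg. Compound 1 `O=C(O)c1cnc(-c2ccccc2F)[nH]c1=O` needs 5 mg/kg, with no change at the digits printed from compound 1 to compound 2 (within the scatter). Compound 3 `COc1ccccc1-c1ncc(C(=O)O)c(=O)[nH]1` needs 10 mg/kg; both a 2.0-fold higher number from compound 1 to compound 3 (0.30 log units; within the scatter) and a 2.0-fold higher number from compound 2 to compound 3 (0.30 log units; within the scatter) stay within the scatter. Compound 2 therefore matches compound 1 and sits close to compound 3 on the numbers shown. Compound 4 `CCCCCOc1ccccc1-c1ncc(C(=O)O)c(=O)[nH]1` differs from compound 2 by pentyloxy in place of chloro on an aromatic carbon. Within the data shown here, the step to compound 3, a methoxy in place of chloro, is the only measured guide, and it gave a small rise in dose within the scatter. Nothing measured shows what a longer chain does. Compound 4 is expected to need about 15 mg/kg, between 5 mg/kg and 50 mg/kg. That estimate means a 3.0-fold higher number from compound 2 to compound 4 (0.48 log units; beyond the scatter) is expected.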

Compound 4, dose for 50% inhibition: 3 mg/kg
Beside the measured number, compound 4's estimate is 5.0-fold (0.70 log units) above it; the measured number lies below the stated range.
By their numbers in this assay, from the lowest: compounds 4, 1, 2 and 3 (each within the scatter of the next, the first and the last beyond it).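

Going from the methoxy of compound 3 to the pentyloxy of compound 4 gives a 3.3-fold lower number from compound 3 to compound 4 (0.52 log units; beyond the scatter), the only step so far beyond the scatter, so at this position a longer chain can lower the dose. Beside the halogens, the chain leaves the dose level: a 1.7-fold lower number from compound 2 to compound 4 (0.22 log units; within the scatter) and a 1.7-fold lower number from compound 1 to compound 4 (0.22 log units; within the scatter), so this larger group is tolerated where chloro and fluoro sit. No measurement here explains this result. Still open, as far as these compounds go, is how intermediate chains such as propoxy behave, and whether a longer octyloxy chain or one ending in an amine would keep the dose this low.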